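This account rests on a few compounds, and the source may have more. Where it says the series, first, only, none or still open, it means among the compounds named here.

Working notes on the series. The three compounds measured share a core in which an acylated ring nitrogen sits next to a carboxamide bearing an aryl group. Compound 1 `CCCCCCCCC(=O)N1c2ccccc2CCC1C(=O)Nc1ccccc1C(F)(F)F` carries a nonanoyl group on the ring nitrogen and a trifluoromethyl on the anilide; in a functional assay on PC-3 cells (Homo sapiens) for cytotoxicity, read by sulforhodamine B assay, with a stated time of 72 h (a lower number here means a stronger inhibitor of growth, a higher number a weaker inhibitor of growth), compound 1 gives 4320 nM. Among the measured compounds shown here, compound 2 `CCCCCCCCC(=O)N1c2ccccc2CCC1C(=O)Nc1ccccc1O` gives 45200 nM in this assay, and the step of a 10-fold higher number from compound 1 to compound 2 (1.02 log units; beyond the scatter) is the only single-point change measured so far. For the measured compounds named here, compound 3 `O=C(Nc1cc(C(F)(F)F)cc(C(F)(F)F)c1)C1CCc2ccccc2N1C(=O)c1ccccc1` gives 3500 nM; it differs from compound 1 in more than one place, and the two values show only that compound 1 and compound 3 sit close together. Among the three, compound 1 stands second highest, nearest to compound 3 and furthest from compound 2.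

Compound 4 `CCCC(=O)N1c2ccccc2CCC1C(=O)Nc1ccccc1C(F)(F)F` is not yet measured. Its change from compound 1 is hydrogen in place of pentyl on a saturated chain carbon, three bonds along the chain from a carbonyl carbon. Going by the values given here, no measured step touches the acyl chain on the ring nitrogen, so nothing here bears directly on this change; the one measured step concerns the anilide only. With the chain cut from nonanoyl to butanoyl, the number is expected to move upward, and the step of a 2.3-fold higher number from compound 1 to compound 4 (0.36 log units; beyond the scatter) is estimated with wide uncertainty. Compound 4 is therefore expected to give about 10000 nM, within the range 3000 nM to 35000 nM.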

Compound 4, concentration for 50% growth inhibition: > 70000 nM
Compound 4: no number, only a limit; the forecaster's own chance of this, stated with the estimate: 5%; at least 7.0-fold (0.84 log units) between middle value and limit.
By their numbers in this assay, from the lowest: compounds 3 and 1 (each within the scatter of the next); then compound 2. At a limit, above all of these: compound 4.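

In this assay compound 4 gives > 70000 nM, which is a limit of the assay and not a number, and it is the only such limit among the values in the series: the limit of > 70000 nM in this assay, at which 1 of the 4 values shown sits. Hydrogen in place of pentyl, on a saturated chain carbon three bonds along the chain from a carbonyl carbon, gives an at least 16-fold higher number from compound 1 to compound 4 (1.20 log units; beyond the scatter), so the true size of this step remains unknown beyond that bound. Among the compounds shown here, until now the only measured single-point change lay on the anilide, and this result shows that the acyl chain on the ring nitrogen also matters for growth inhibition: with the trifluoromethyl anilide held constant, shortening nonanoyl to butanoyl gives a large step beyond the scatter.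

With only the nonanoyl and butanoyl chains to compare, the compounds shown do not tell whether the number climbs gradually or abruptly at a chain length in between, such as hexanoyl. They also leave open what a longer chain, such as dodecanoyl, or a chain ending in an amine or a carboxylic acid would give at this position.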